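Working notes: from compound 3 to compound 4

A few compounds are considered here, and "the series" means these few. Any claim that something is new, unique, unknown or untested is made for them only; others in the source may bear on it.

compound 1 `O=C(N/N=C/c1ccc(O)c(O)c1)c1cccnc1Nc1cccc(C(F)(F)F)c1` gives 21.1%
compound 2 `CN(C)c1ccc(/C=N/NC(=O)c2cccnc2Nc2cccc(C(F)(F)F)c2)cc1` gives 28.2%
compound 3 `CNc1ncccc1C(=O)N/N=C/c1ccccc1` gives 14.8%

All three numbers come from a functional assay on the whole organism (strain Wistar) for inhibition, with Rattus norvegicus as the target, read by paw edema, with a stated time of 4 h, at a dose of 10 mg/kg by the intraperitoneal route; a lower number here means less inhibition, a higher number more inhibition at the dose given (going by the name of the read-out). Compound 3 stands lowest of the three; its nearest neighbour is compound 1, within the scatter, while the gap to compound 2 lies beyond the scatter. Compound 4 `CNc1ncccc1C(=O)N/N=C/c1cccc(Cl)c1` differs from compound 3 by chloro in place of hydrogen on an aromatic carbon, the chlorine sitting meta to a large group. Among the compounds with values here, no measured step exchanges hydrogen for chloro. Within the data shown here, the only single-place step available, a number 7.1 percentage points higher from compound 1 to compound 2 (within the scatter), replaces one substituted phenyl by another on the same kind of ring and stays within the scatter, and it belongs to a core different from that of compound 3. For compound 4 a step no larger than the scatter is therefore expected, a number 2.2 percentage points higher from compound 3 to compound 4 (within the scatter). Compound 4 is estimated at 17%, with a range from 7% to 28%.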

Compound 4, a percentage reported as inhibition, in the whole organism at one dose (the size of the read-out at that dose, not a potency): 40.4%
The estimate for compound 4 lay 23.4 percentage points below the measured number; the whole stated range lies below it.
By their numbers in this assay, from the lowest: compounds 3, 1 and 2 (each within the scatter of the next, the first and the last beyond it); then compound 4.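

The step of a number 25.6 percentage points higher from compound 3 to compound 4 (beyond the scatter) in this assay comes from chloro in place of hydrogen on an aromatic carbon, meta to a large group. Within the data shown here, the only earlier single-place step lay within the scatter, whereas this one change of a single heavy atom on the core of compound 3 moves the read-out beyond it. Nothing at hand bears on the reason for this step. As far as these compounds go, whether the rise is particular to chloro remains open. A fluoro, methyl or methoxy group at this same place would address that.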